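Swapping fluoro for trifluoromethyl on a biaryl sulfonamide

The compounds below may be only part of what the source reports. "The series", "measured", "known", "first", "only" and "open" are said of these compounds alone.

Three compounds have been examined in an ADME assay on S9 fraction from liver (Mus musculus, strain ICR/CD-1) for metabolic stability, read by LC-MS, using NADPH, with a stated time of 5 min, tested at 2 uM; a higher number here means that the compound lasts longer, a lower number that the compound disappears faster. Compound 1 `CC1CCN(C2CCN(S(=O)(=O)c3cccc4ccccc34)CC2)CC1` is reported only as a limit of the method, < 0.0834 h. Compound 3 `Cc1cc(S(=O)(=O)N2CCC(N3CCC(C)CC3)CC2)c(Cl)cc1Cl` gives 0.108 h. Compound 2 `CC1CCN(C2CCN(S(=O)(=O)c3cccc(-c4ccccc4F)c3)CC2)CC1` gives 0.283 h, the higher of the two actual numbers; its nearest neighbour is compound 3, whose value lies lower by a gap beyond the usual scatter. Compound 4 `CC1CCN(C2CCN(S(=O)(=O)c3cccc(-c4ccccc4C(F)(F)F)c3)CC2)CC1` has not yet been measured; it differs from compound 2 by trifluoromethyl in place of fluoro on an aromatic carbon. Among the measured compounds shown here, no measured pair shows this change, so the direction of the step is open, and a step in this assay no larger than the usual scatter is expected. The half-life of compound 4 is therefore estimated at 0.3 h, with a range from 0.12 h to 0.7 h, corresponding to an expected step of a 1.1-fold higher number from compound 2 to compound 4 (0.03 log units; within the scatter).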

Compound 4, half-life: 0.617 h
Estimate against measurement, compound 4: 2.1-fold (0.31 log units) below; the range from low to high includes it.
By their numbers in this assay, from the lowest: compound 3; then compound 2; then compound 4. At a limit, below all of these: compound 1.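

In this assay, trifluoromethyl in place of fluoro on an aromatic carbon, ortho to a large group, gives a 2.2-fold higher number from compound 2 to compound 4 (0.34 log units; beyond the scatter). Among the compounds shown here, this is the first measured pair here that differs in one place, and it shows that the half-life responds to what sits at this position, with trifluoromethyl going with the longer one. It is a single pair, so it sets no trend.

From the compounds shown here alone, whether a nitrile or an amine at this position would give a longer or shorter half-life stays open. Compound 1 stands only as a limit: the limit of < 0.0834 h in this assay, at which 1 of the 4 values shown sits.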